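The source may report more compounds than this note shows. Statements on the series, on what has been measured and on what is new or still open speak of the compounds shown alone.

Compound 1 `CO[C@H]1C[C@H](C)Cc2cc(O)cc(c2)NC(=O)/C=C/CC[C@H](OC)[C@@H](OC(N)=O)/C(C)=C/[C@H](C)[C@H]1O` gives > 10000 nM in a functional assay on HCT-116 cells (Homo sapiens) for inhibition (a lower number here means a stronger inhibitor of growth, a higher number a weaker inhibitor of growth), which is a limit of the assay rather than a number. Compound 2 `CO[C@H]1C[C@H](C)Cc2cc(cc(O)c2O)NC(=O)/C(C)=C/CC[C@H](OC)[C@@H](OC(N)=O)/C(C)=C/[C@H](C)[C@H]1O` gives 8910 nM in this assay.

For the measured compounds named here, compound 2 thus holds the only actual number here; the one other value sits at the limit of > 10000 nM in this assay, at which 1 of the 2 values shown sits. Compound 3 `CO[C@H]1C[C@H](C)Cc2cc(O)cc(c2)NC(=O)/C(C)=C/CC[C@H](OC)[C@@H](OC(N)=O)/C(C)=C/[C@H](C)[C@H]1O` differs from compound 2 by hydrogen in place of hydroxy on an aromatic carbon. Going by the values given here, no measured pair shares this change, so its effect is untested. Compound 3 is expected to remain a weak growth inhibitor, with a step from compound 2 of a 1.7-fold higher number from compound 2 to compound 3 (0.23 log units; within the scatter), leaning toward weaker and possibly only a limit. The estimate for compound 3 is 15000 nM, between 5000 nM and 50000 nM.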

Compound 3, concentration for 50% growth inhibition: 780 nM
The estimate for compound 3 lay 19-fold (1.28 log units) above the measured number; measured number outside the range, below it.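

In this assay replacing the hydroxy group on this aromatic carbon with hydrogen gives an 11-fold lower number from compound 2 to compound 3 (1.06 log units; beyond the scatter) and so shows that this position is far from indifferent. For the compounds shown here, of the two groups compared here, the hydroxy group goes with the weaker growth inhibition, which no earlier pair could show. Nothing measured here explains the size of this step.

Going by these compounds, whether a fluorine atom or an amine on the same carbon would match hydrogen or hydroxy remains open. So does whether this change would have the same effect on a different core.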